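The source may hold more compounds than are shown below. What is called first, only, known or untested is meant among the compounds shown, and "the series" means these compounds.

Measured compounds in a functional assay on AGS cells (Homo sapiens) for cytotoxicity, read by MTT assay, with a stated time of 48 h; a higher number here means a weaker inhibitor, a lower number a stronger inhibitor:
compound 1 `Cc1nc2c3ccccc3ccc2c2nc3c(ccc4ccccc43)c(-c3ccccc3Cl)c12`: 52500 nM
compound 2 `Cc1nc2c3ccccc3ccc2c2nc3c(ccc4ccccc43)c(-c3cc([N+](=O)[O-])ccc3N)c12`: 17800 nM
compound 3 `Cc1nc2c3ccccc3ccc2c2nc3c(ccc4ccccc43)c(-c3ccccc3)c12`: > 80000 nM

Compound 3 stands only at a limit of the assay, not at a number, as the limit of > 80000 nM in this assay, at which 1 of the 3 values shown sits, records. Among the three measured compounds it therefore gives the weakest inhibition that the shown numbers can resolve, though its step from compound 1, an at least 1.5-fold higher number from compound 1 to compound 3 (0.18 log units; that floor lies within the scatter), has a floor within the scatter.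

Compound 4 `Cc1nc2c3ccccc3ccc2c2nc3c(ccc4ccccc43)c(-c3ccc(O)cc3)c12` follows from compound 3 by the change (hydroxy in place of hydrogen on an aromatic carbon).

Among the compounds with values here, two measured steps touch the same phenyl ring. The step of an at least 1.5-fold higher number from compound 1 to compound 3 (0.18 log units; that floor lies within the scatter) is small and uncertain. The step of an at least 4.4-fold higher number from compound 2 to compound 3 (0.65 log units; beyond the scatter) shows that a 2-amino-5-nitrophenyl ring in place of bare phenyl gives a clearly lower number. Both steps point the same way: a substituent on that ring lowers the number, bare phenyl sits at the limit. A single hydroxy is a smaller change than either measured substitution, so a step downward that is modest at best is expected, an at least 1.3-fold lower number from compound 3 to compound 4 (0.12 log units; that floor lies within the scatter), with a fair chance that compound 4 also returns only a limit.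

Compound 4 is thus estimated at 60000 nM, within 25000 nM to 150000 nM.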

Compound 4, half-maximal inhibitory concentration: 14200 nM
Estimate against measurement, compound 4: 4.2-fold (0.63 log units) above; the whole stated range lies above it.
By their numbers in this assay, from the lowest: compounds 4 and 2 (each within the scatter of the next); then compound 1. At a limit, above all of these: compound 3.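

In this assay, a single hydroxy para to a large group is enough to move the ring off the limit: an at least 5.6-fold lower number from compound 3 to compound 4 (0.75 log units; beyond the scatter). Compound 3 remains a limit and not a number: the limit of > 80000 nM in this assay, at which 1 of the 4 values shown sits. The one-atom change from phenyl to 4-hydroxyphenyl reaches the level of the doubly substituted ring, with a 1.3-fold lower number from compound 2 to compound 4 (0.10 log units; within the scatter), and it also separates from the 2-chlorophenyl ring, with a 3.7-fold lower number from compound 1 to compound 4 (0.57 log units; beyond the scatter), so at this position the identity and place of the group count for more than the number of substituents in these compounds.

Open, from the compounds shown here alone, is whether the hydroxy itself is needed, or whether a methoxy, an amine or a carboxylic acid at the same place would give a similar number. Also open, going by these compounds, is how a hydroxy elsewhere on this ring would read.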